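The source may hold more compounds than are shown below. What is called first, only, known or untested is meant among the compounds shown, and "the series" means these compounds.

Compound 1 `COC(=O)C(=N)/C=C(\O)c1ccc(F)cc1` gives 1% in an assay for inhibition of kynurenine 3-monooxygenase (Rattus norvegicus), tested at 10 uM; on this read-out higher numbers stand for more inhibition at the one concentration tested (going by the name of the read-out) and lower numbers for less inhibition. Compound 2 `COC(=O)C(=N)/C=C(\O)c1ccc(F)c(Cl)c1` gives 4% in this assay; the change is chloro in place of hydrogen on an aromatic carbon and the step is a number 3 percentage points higher from compound 1 to compound 2 (within the scatter). Compound 3 `N/C(=C\C(=O)c1ccccc1)C(=O)O` gives 17% in this assay, the highest of the three numbers, beyond the scatter from compound 2 and from compound 1. The difference between the core of compound 3 and the core of compound 1 is not broken down here. Compound 4 `N/C(=C\C(=O)c1ccccc1Cl)C(=O)O` is not yet measured; relative to compound 3 it carries chloro in place of hydrogen on an aromatic carbon. This is the same kind of change as that made from compound 1 to compound 2, but the place differs: there the chloro sits ortho to a fluoro group and meta to a group of 9 heavy atoms, here ortho to a group of 8 heavy atoms. Because a number 3 percentage points higher from compound 1 to compound 2 (within the scatter) lay within the scatter, a step of similar size is expected, namely a number 3 percentage points higher from compound 3 to compound 4 (within the scatter). Compound 4 is accordingly estimated at 20% in this assay, between 8% and 35%.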

Compound 4, a percentage reported as inhibition, at one concentration (the size of the read-out at that concentration, not a potency): 19%
Beside the measured number, compound 4's estimate is 1 percentage points above it, and the stated range covers the measured number.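

In this assay the step for chloro in place of hydrogen on an aromatic carbon is a number 2 percentage points higher from compound 3 to compound 4 (within the scatter). Set beside the earlier step, the change shows no difference between the two cores: the same change on two cores in this assay, a number 3 percentage points higher (within the scatter) from compound 1 to compound 2 and a number 2 percentage points higher (within the scatter) from compound 3 to compound 4, 1 percentage points apart, within the scatter of two such steps. This shows that the change stays within the scatter on both cores, with the chloro in a different place on each, but not that it would do so on other cores or that place makes no difference.

Open, from the compounds shown here alone, is whether a nitrile or a methoxy group on the same ring would give a step beyond the scatter. Also open, going by these compounds, is what an amide would give in place of the ester of compound 1 or the carboxylic acid of compound 3.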